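This account rests on a few compounds, and the source may have more. Where it says the series, first, only, none or still open, it means among the compounds named here.

Measured in a functional assay on HEL cells (Homo sapiens); on this read-out lower numbers stand for higher toxicity in this test and higher numbers for lower toxicity in this test:
- Compound 1 `CCCCCCCc1cc2cn(COCCO)c(=O)nc2o1`: 140000 nM
- Compound 2 `CCCCC#Cc1cc2cn(COCCO)c(=O)nc2o1`: > 50000 nM (a limit of the assay, not a number)

Compound 2 therefore has no exact place on the scale. Its standing is only this: the limit of > 50000 nM in this assay, at which 1 of the 2 values shown sits.

The next compound, compound 3 `CCCCCc1cc2cn(COCCO)c(=O)nc2o1`, keeps the shared core and changes one group: pentyl in place of hex-1-yn-1-yl on an aromatic carbon. Pentyl replaces hex-1-yn-1-yl on an aromatic carbon, next to the ring oxygen.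

Among the measured compounds shown here, only one measured step bears on this change, a step that the limit leaves unreadable from compound 1 to compound 2. It swaps a chain of the same kind in the same place, but it gives no size to carry forward. The best numerical guide is compound 1, which carries heptyl and gives 140000 nM. Compound 3 also carries a plain alkyl chain, so a value in the same high region is expected, meaning low toxicity in this assay.

With no number for compound 2, the expected step that the limit leaves unreadable from compound 2 to compound 3 is only a rough estimate, and its direction is tentative. For compound 3 the estimated value is 120000 nM, with an expected range from 50000 nM to 250000 nM.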

Compound 3, half-maximal cytotoxic concentration: > 200000 nM
Compound 3: no number, only a limit; the forecaster's own chance of this, stated with the estimate: 55%; at least 1.6-fold (0.22 log units) between middle value and limit.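

With pentyl in place of heptyl on this aromatic carbon, next to the ring oxygen, this assay shows an at least 1.4-fold higher number from compound 1 to compound 3 (0.15 log units; that floor lies within the scatter). Shortening this saturated chain therefore brings no sign of greater toxicity, although the floor of that step does not by itself establish a real rise in the number. Compound 3 gives only a limit, not an exact value, and the steps that involve compound 2 cannot be read: the limit of > 200000 nM in this assay, at which 1 of the 3 values shown sits.

Going by these compounds, without exact values for compound 2 and compound 3, it remains unknown where compound 3 truly lies on the scale and whether the triple bond of hex-1-yn-1-yl makes any difference compared with the saturated chains. Also open, on these data alone, is what a longer chain such as decyl, or a chain ending in an amine or a phenyl ring, would give at this place in this assay.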